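The source may hold more compounds than are shown below. What is called first, only, known or untested is meant among the compounds shown, and "the series" means these compounds.

Compound 1 `COc1ccc(CN(C(=O)CSC(=S)N2CCN(C(C)=O)CC2)c2cc(OC)c(OC)c(OC)c2)cc1` is the reference of this small set. In a functional assay on MGC-803 cells (Homo sapiens) for inhibition, read by CCK-8 assay, with a stated time of 48 h (on this read-out higher numbers stand for weaker inhibition and lower numbers for stronger inhibition), compound 1 gives 480 nM. Compound 2 `COc1ccc(CN(C(=O)CSC(=S)N2CCN(C(=O)OC(C)(C)C)CC2)c2cc(OC)c(OC)c(OC)c2)cc1` differs from compound 1 by tert-butoxy in place of methyl on a carbonyl carbon; in this assay compound 2 gives 310 nM, and the change made a 1.5-fold lower number from compound 1 to compound 2 (0.19 log units; within the scatter). Compound 3 `COc1ccc(CN(C(=O)CN2CCN(C(C)=O)CC2)c2cc(OC)c(OC)c(OC)c2)cc1` has a different core, and the difference between the core of compound 1 and the core of compound 3 is a group of 9 heavy atoms (6 carbon, 2 nitrogen, 1 oxygen; one six-membered non-aromatic ring with 2 hetero atoms) in place of a group of 12 heavy atoms (7 carbon, 2 nitrogen, 1 oxygen, 2 sulfur; one six-membered non-aromatic ring with 2 hetero atoms), on a saturated chain carbon bound to a carbonyl carbon. In this assay compound 3 gives 12800 nM, so the change of core made a 27-fold higher number from compound 1 to compound 3 (1.43 log units; beyond the scatter). Compound 4 `COc1ccc(CN(C(=O)CN2CCN(C(=O)OC(C)(C)C)CC2)c2cc(OC)c(OC)c(OC)c2)cc1` has not yet been measured. It differs from compound 3 by tert-butoxy in place of methyl on a carbonyl carbon, the same change that leads from compound 1 to compound 2, at the same place. On that basis compound 4 is expected to show a 1.3-fold lower number from compound 3 to compound 4 (0.13 log units; within the scatter). The expectation rests on compound 1, where the same change made a 1.5-fold lower number from compound 1 to compound 2 (0.19 log units; within the scatter), a step within the scatter. Compound 4 is therefore estimated at 9500 nM in this assay, with a likely range from 3500 nM to 25000 nM.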

Compound 4, half-maximal inhibitory concentration: 9500 nM
Estimate against measurement, compound 4: no gap at the digits printed; measured number inside the range.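

In this assay, the change from acetyl to tert-butoxycarbonyl gives a 1.3-fold lower number from compound 3 to compound 4 (0.13 log units; within the scatter), and the earlier step on the core of compound 1 agrees with it: the same change on two cores in this assay, a 1.5-fold lower number (0.19 log units; within the scatter) from compound 1 to compound 2 and a 1.3-fold lower number (0.13 log units; within the scatter) from compound 3 to compound 4, 1.1-fold (0.06 log units) apart, within the scatter of two such steps. Within this pair of cores, the change therefore carries over with no difference that can be told from the scatter, and on neither core does it shift the number beyond the scatter. Among the compounds shown here, this shows only that the swap is close to silent on these two cores; it does not show that a change with a large effect would carry over in the same way, nor does it speak for any third core.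

What the compounds leave open is how other groups on that carbonyl carbon would read on the two cores, such as an amine, a phenyl ring or a longer chain. They also leave open whether the agreement holds in any cell line other than the one shown here.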